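This account rests on a few compounds, and the source may have more. Where it says the series, first, only, none or still open, it means among the compounds named here.

In a functional assay on U2OS cells (Homo sapiens) for cytotoxicity, read by MTT assay, with a stated time of 48 h (on this read-out higher numbers stand for weaker inhibition and lower numbers for stronger inhibition), compound 2 (`Fc1ccc2nc(-c3ccccc3)nc(Nc3ccccc3)c2c1`) gives > 50000 nM, which is a limit of the assay and not a number. Compound 1 (`Fc1cccc(-c2nc(Nc3ccccc3)c3ccccc3n2)c1`) gives > 50000 nM, likewise a limit. Both values shown sit at the limit of > 50000 nM in this assay, at which 2 of the 2 values shown sit, so compound 2 cannot be ranked against any other compound on the numbers available. Compound 3 (`Fc1cccc(-c2nc(Nc3ccccc3)c3cc(F)ccc3n2)c1`) differs from compound 2 by fluoro in place of hydrogen on an aromatic carbon. Among the measured compounds shown here, no step between measured compounds is available for comparison; in this assay no shift beyond the scatter is expected in either direction, so the estimated step that the limit leaves unreadable from compound 2 to compound 3 is small. Compound 3 is expected at 80000 nM, range 30000 nM to 300000 nM, most probably reported again as a limit only.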

Compound 3, half-maximal inhibitory concentration: 47600 nM
Beside the measured number, compound 3's estimate is 1.7-fold (0.23 log units) above it; the measured number falls inside the stated range.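

In this assay compound 3 alone of the three carries a number and not a limit, so the phenyl to 3-fluorophenyl change can now be given a floor: the step reads an at least 1.0-fold lower number from compound 2 to compound 3 (0.02 log units; that floor lies within the scatter). The other fluoro for hydrogen change reads an at least 1.0-fold lower number from compound 1 to compound 3 (0.02 log units; that floor lies within the scatter). Both floors lie within the scatter, so a real gain from the added fluoro is neither shown nor excluded.

Still open, as far as these compounds go, is the true size of either step. Also open, from the compounds shown here alone, is whether an amine or a carboxylic acid at this position would give a number clearly lower than that of compound 3.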